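Removing a protecting group on a pancreatic-cell growth inhibitor

The source may report more compounds than this note shows. Statements on the series, on what has been measured and on what is new or still open speak of the compounds shown alone.

Four compounds sharing one core are compared in a functional assay on PANC-1 cells (Homo sapiens) for inhibition, read by MTT assay, with a stated time of 72 h; on this read-out lower numbers stand for stronger inhibition and higher numbers for weaker inhibition. Compound 1 `CC(C)(C)OC(=O)NCCOc1cc(NC(=O)c2cnccn2)c2ncccc2c1` gives 9500 nM in this assay. Compound 2 `NCCOc1cc(NC(=O)c2cnccn2)c2ncccc2c1` carries hydrogen in place of tert-butoxycarbonyl on an amine nitrogen. In this assay compound 2 reaches only a limit of the assay, > 10000 nM. The step of an at least 1.0-fold higher number from compound 1 to compound 2 (0.02 log units; that floor lies within the scatter) is therefore known only as a floor. Compound 3 `CC(C)(C)OC(=O)NCCOc1cc(NC(=O)c2ncccn2)c2ncccc2c1` differs from compound 1 in the core by pyrimidin-2-yl in place of pyrazin-2-yl on a carbonyl carbon. In this assay compound 3 also gives only a limit of the assay, > 10000 nM. The step of an at least 1.0-fold higher number from compound 1 to compound 3 (0.02 log units; that floor lies within the scatter) is again a floor. Both floors rest on (the limit of > 10000 nM in this assay, at which 2 of the 3 values shown sit). Compound 4 `NCCOc1cc(NC(=O)c2ncccn2)c2ncccc2c1` has not yet been measured. It carries from compound 3 the same change that compound 2 carries from compound 1, namely (hydrogen in place of tert-butoxycarbonyl on an amine nitrogen), at the same place. Compound 4 is expected to move by a step that the limit leaves unreadable from compound 3 to compound 4 from compound 3. That expectation rests on the earlier step of an at least 1.0-fold higher number from compound 1 to compound 2 (0.02 log units; that floor lies within the scatter), which ended at the limit. The estimate for compound 4 in this assay is 15000 nM, expected between 8000 nM and 40000 nM, most likely reported only as a limit.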

Compound 4, half-maximal inhibitory concentration: > 10000 nM
Compound 4: no number, only a limit; the forecaster's own chance of this, stated with the estimate: 85%; the middle value does not contradict the limit.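

The steps from compound 3 to compound 4 and from compound 2 to compound 4 cannot be read, because all three compounds give only a limit and no number: the limit of > 10000 nM in this assay, at which 3 of the 4 values shown sit. The compounds shown leave open whether either hydrogen in place of tert-butoxycarbonyl or pyrimidin-2-yl in place of pyrazin-2-yl changes inhibition at all.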